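Swapping furan-2-yl for furan-3-yl at the assay limit

The source may hold more compounds than are shown below. What is called first, only, known or untested is meant among the compounds shown, and "the series" means these compounds.

In a functional assay on K562 cells (Homo sapiens), read by MTT assay, with a stated time of 72 h (a higher number here means a weaker inhibitor, a lower number a stronger inhibitor), compound 1 (`Nc1nc(N)c2c(-c3ccco3)cn([C@@H]3O[C@H](CO)[C@@H](O)[C@H]3O)c2n1`) gives > 20000 nM as its result, which is a limit of the assay and not a number. Compound 2 (`Cc1nc(N)c2c(-c3ccco3)cn([C@@H]3O[C@H](CO)[C@@H](O)[C@H]3O)c2n1`) gives > 20000 nM as its result, again only a limit. Compound 2 therefore has no number of its own, and the data hold the limit of > 20000 nM in this assay, at which 2 of the 2 values shown sit, and nothing firmer. Among the compounds with values here, the one measured step is a step that the two limits leave unreadable from compound 1 to compound 2 and so offers no size to carry forward.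

Compound 3 (`Cc1nc(N)c2c(-c3ccoc3)cn([C@@H]3O[C@H](CO)[C@@H](O)[C@H]3O)c2n1`) differs from compound 2 only in its furan ring (furan-3-yl in place of furan-2-yl on an aromatic carbon). Furan-3-yl stands in place of furan-2-yl on an aromatic carbon of the shared core. Within the data shown here, no measured step bears on this exchange, so no step beyond the scatter is expected in this assay and no direction can be given. Compound 3 is expected to stay close to compound 2, whose result of > 20000 nM is a limit. The expected size is a number no higher from compound 2 to compound 3 (the limit leaves the size open) on this reasoning. For compound 3 the estimated value is 20000 nM with an expected range from 8000 nM to 50000 nM and a result given only as a limit is the likeliest outcome.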

Compound 3, half-maximal inhibitory concentration: > 20000 nM
Compound 3 was reported as a limit; the forecaster's own chance of this, stated with the estimate: 75%; the middle value lies on the limit itself.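

In this assay compound 3 gives > 20000 nM, which is a limit of the assay and not a number. The step between compound 2 and compound 3 cannot be read. The data hold only one limit: the limit of > 20000 nM in this assay, at which 3 of the 3 values shown sit. The compounds shown leave open what number any of them would reach, and whether furan-2-yl and furan-3-yl differ at all.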